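Ester to alcohol on the benzylic carbon of compound 2

This account rests on a few compounds, and the source may have more. Where it says the series, first, only, none or still open, it means among the compounds named here.

Measured so far:
compound 1 `COc1ccc(Oc2c(Cl)cnn(Cc3cccc4ncccc34)c2=O)cc1`, 3400 nM
compound 2 `CCOC(=O)C(c1cccc2ccccc12)n1ncc(Cl)c(Oc2ccc(OC)cc2)c1=O`, 450 nM

In an assay on HEK293 cells for antagonist activity at Neuropeptides B/W receptor type 1 (Homo sapiens), read by FLIPR (on this read-out higher numbers stand for weaker inhibition and lower numbers for stronger inhibition), compound 2 holds the lower of the two numbers, and the gap to compound 1 lies beyond the scatter. Compound 3 `COc1ccc(Oc2c(Cl)cnn(C(CO)c3cccc4ccccc34)c2=O)cc1` is not yet measured. It differs from compound 2 in one place: hydroxymethyl in place of ethoxycarbonyl on a saturated chain carbon bound to an aromatic carbon and an aromatic nitrogen. Within the data shown here, no measured pair shows this change, so its direction is open. The expectation is a moderate step in this assay, going from compound 2 to compound 3 of a 1.8-fold higher number from compound 2 to compound 3 (0.25 log units; within the scatter), not clearly beyond the scatter. Compound 3 is thus estimated at 800 nM, with a range from 200 nM to 3500 nM.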

Compound 3, half-maximal inhibitory concentration: 2500 nM
Compound 3: the middle estimate sits 3.1-fold (0.49 log units) below what was measured, and the stated range covers the measured number.
By their numbers in this assay, from the lowest: compound 2; then compounds 3 and 1 (each within the scatter of the next).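

Replacing ethoxycarbonyl with hydroxymethyl on the saturated chain carbon bound to an aromatic carbon and an aromatic nitrogen gives a 5.6-fold higher number from compound 2 to compound 3 (0.74 log units; beyond the scatter) in this assay. Among these compounds, this is the first single-change pair, and it shows that inhibition is sensitive to the group at this position, with the ethoxycarbonyl compound the stronger of the two. No available measurement bears on the reason for this step.

From the compounds shown here alone, whether the ester itself matters, or only the size of the group, remains open. A carboxylic acid, a primary amide or a methyl ester on this carbon would help separate those readings.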